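From ethoxy to isopropoxy on a shared core

This account rests on a few compounds, and the source may have more. Where it says the series, first, only, none or still open, it means among the compounds named here.

In a functional assay on MCF7 cells (Homo sapiens) for antiproliferative activity, read by sulforhodamine B assay, with a stated time of 72 h (a lower number here means a stronger inhibitor, a higher number a weaker inhibitor), compound 1 (`O=C(/C=C/c1csc2ccccc12)c1cc(F)ccc1O`) gives > 10000 nM as its reading, which is a limit of the assay and not a number. Among the compounds with values here, compound 2 (`CCOc1ccc(O)c(C(=O)/C=C/c2csc3ccccc23)c1`) gives 7500 nM as the only actual number so far. Compound 3 (`CC(C)Oc1ccc(O)c(C(=O)/C=C/c2csc3ccccc23)c1`) differs from compound 2 by methyl in place of hydrogen on a saturated chain carbon bound to an oxygen on an aromatic ring and a saturated chain carbon as ethoxy becomes isopropoxy. Within the data shown here, the one measured step (an at least 1.3-fold lower number from compound 1 to compound 2 (0.12 log units; that floor lies within the scatter)) is only a floor within the scatter, so no step beyond the scatter is expected in this assay for this change. The expected step is a 1.1-fold lower number from compound 2 to compound 3 (0.03 log units; within the scatter) in size. Compound 3 is estimated at 7000 nM with 3500 nM to 15000 nM as the expected range.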

Compound 3, half-maximal inhibitory concentration: 6600 nM
For compound 3 the middle estimate is 1.1-fold (0.03 log units) above the measured one, and the stated range covers the measured number.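

In this assay, within the data shown here, the change from ethoxy to isopropoxy gives a 1.1-fold lower number from compound 2 to compound 3 (0.06 log units; within the scatter), the first step here between two actual numbers, so this added methyl leaves the reading indistinguishable from that of the ethoxy compound. Isopropoxy in place of fluoro gives an at least 1.5-fold lower number from compound 1 to compound 3 (0.18 log units; that floor lies within the scatter), and this is only a floor because the reading for compound 1 is a limit: the limit of > 10000 nM in this assay, at which 1 of the 3 values shown sits.

Going by these compounds, whether a longer chain such as butoxy, or an amine in place of the ethoxy group, would move the number beyond the scatter remains open.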